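The compounds below may be only part of what the source reports. "The series", "measured", "known", "first", "only" and "open" are said of these compounds alone.

Compound 1 `CC1CCN(C2CCN(S(=O)(=O)c3ccc(F)cc3F)CC2)CC1` was examined in an ADME assay on HCT-116 cells (Homo sapiens) for cytotoxicity, read by CellTiter-Glo, with a stated time of 72 h; a higher number here means a weaker inhibitor, a lower number a stronger inhibitor. Its result in this assay is reported only as a limit of the assay and not as a number: compound 1 gives > 5000 nM. Compound 2 `CC1CCN(C2CCN(C(=O)c3ccc(OC(F)(F)F)cc3)CC2)CC1` is likewise reported at a limit in this assay, and compound 2 gives > 5000 nM. Compound 3 `Cc1cc(C)c(S(=O)(=O)N2CCC(c3ccccc3)CC2)c(C)c1` also sits at a limit in this assay, where compound 3 gives > 5000 nM. Compound 1 thus stands nowhere apart from the other two, because all three rest at the limit of > 5000 nM in this assay, at which 3 of the 3 values shown sit. Among the measured compounds shown here, no step between two measured compounds is available here; none differs from another in a single place.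

Compound 4 `CC1CCN(C2CCN(S(=O)(=O)c3cccnc3)CC2)CC1` has not yet been measured in this assay. It differs from compound 1 in one respect, (pyridin-3-yl in place of 2,4-difluorophenyl on a sulfonyl sulfur). With every measured value resting at a limit, no direction can be drawn from the data, and the step is expected to stay within the scatter, a step that the limit leaves unreadable from compound 1 to compound 4. Compound 4 is therefore expected to give about 10000 nM in this assay, within 5000 nM to 30000 nM, with a strong chance that only a limit is again reported.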

Compound 4, half-maximal inhibitory concentration: > 10000 nM
Compound 4 ended at the assay's limit; the forecaster's own chance of this, stated with the estimate: 85%; the middle value lies on the limit itself.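

In this assay compound 1 gives > 5000 nM, which is a limit of the assay. Among the compounds shown here, compound 4 gives > 10000 nM, also a limit, so no step between compound 1 and compound 4 can be read. The compounds shown leave open whether pyridin-3-yl in place of 2,4-difluorophenyl on a sulfonyl sulfur changes the result in this assay at all.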